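A few compounds are considered here, and "the series" means these few. Any claim that something is new, unique, unknown or untested is made for them only; others in the source may bear on it.

Compound 1, `C=CC(=O)Nc1cccc(NC(=O)CSc2nc(Nc3ccccc3)c3ccccc3n2)c1`, gives 7310 nM in a functional assay on MGC-803 cells (Homo sapiens) for inhibition, read by MTT assay, with a stated time of 72 h; on this read-out higher numbers stand for weaker inhibition and lower numbers for stronger inhibition.
Compound 2, `C=CC(=O)Nc1cccc(NC(=O)CSc2nc(Nc3ccccc3Cl)c3ccccc3n2)c1`, gives 20700 nM in this assay.
Compound 3, `C=CC(=O)Nc1cccc(NC(=O)CSc2nc(Nc3cccc(C)c3)c3ccccc3n2)c1`, gives 20900 nM in this assay.

Among these three, compound 3 carries the highest number. Its nearest neighbour is compound 2, which sits within the scatter of it, while compound 1 lies further off, with the step of a 2.9-fold higher number from compound 1 to compound 3 (0.46 log units; beyond the scatter) being beyond the scatter.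

The next compound, compound 4, `C=CC(=O)Nc1cccc(NC(=O)CSc2nc(Nc3ccc(Cl)c(Cl)c3)c3ccccc3n2)c1`, comes from compound 3 by a single exchange: 3,4-dichlorophenyl in place of 3-methylphenyl on a nitrogen on an aromatic ring. Three measured steps speak to this exchange. Adding a single group to that phenyl ring weakened inhibition in both cases seen so far: a 2.8-fold higher number from compound 1 to compound 2 (0.45 log units; beyond the scatter) and a 2.9-fold higher number from compound 1 to compound 3 (0.46 log units; beyond the scatter). Swapping one such group for another changed little: a 1.0-fold higher number from compound 2 to compound 3 (0.00 log units; within the scatter). Compound 4 carries two chlorines on that ring, an arrangement not yet seen, so the outlook rests on thin ground. The measured steps suggest that a substituted ring at this place lands near compound 2 and compound 3 rather than back at compound 1, so the expected step from compound 3 to compound 4 is a 1.1-fold higher number from compound 3 to compound 4 (0.02 log units; within the scatter). Compound 4 is therefore estimated at 22000 nM in this assay, within a range of 8000 nM to 60000 nM.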

Compound 4, half-maximal inhibitory concentration: > 50000 nM
Compound 4 gave a limit, no number (the forecaster's own chance of this, stated with the estimate: 10%); middle value at least 2.2-fold (0.35 log units) away from the limit.
By their numbers in this assay, from the lowest: compound 1; then compounds 2 and 3 (each within the scatter of the next). At a limit, above all of these: compound 4.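

In this assay compound 4 gave no number, only a limit of the assay: the limit of > 50000 nM in this assay, at which 1 of the 4 values shown sits. The two rings carrying a single group had given values within the scatter of each other, which could suggest that a substituted ring settles at one level, yet the 3,4-dichlorophenyl group does not stay at that level, as shown by an at least 2.3-fold higher number from compound 3 to compound 4 (0.37 log units; beyond the scatter) and by an at least 2.4-fold higher number from compound 2 to compound 4 (0.38 log units; beyond the scatter). Set against the plain phenyl ring the gap is wider still, at an at least 6.8-fold higher number from compound 1 to compound 4 (0.83 log units; beyond the scatter), so all three substituted rings shown give weaker inhibition than phenyl, and none of the compounds shown goes against this.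

The limit leaves open how far these steps really reach, and the compounds shown cannot separate the part played by each of the two chlorines in the 3,4-dichlorophenyl group. Also open, as far as these compounds go, is whether any group on this ring, such as a methoxy group, an amine or a carboxylic acid, could match or improve on the plain phenyl ring in this assay.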